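Halophenyl amide variation on a shared core

The source may hold more compounds than are shown below. What is called first, only, known or untested is meant among the compounds shown, and "the series" means these compounds.

Measured compounds:
compound 1 `CN(C)C(=O)c1cc2cnc(Nc3ccc(NC(=O)C4(C(=O)Nc5ccc(Cl)cc5)CC4)cc3)nc2n1C1CCCC1` gives 95%
compound 2 `CN(C)C(=O)c1cc2cnc(Nc3ccc(NC(=O)C4(C(=O)Nc5cccc(Cl)c5)CC4)cc3)nc2n1C1CCCC1` gives 92.6%
compound 3 `COc1cccc(NC(=O)C2(C(=O)Nc3ccc(Nc4ncc5cc(C(=O)N(C)C)n(C6CCCC6)c5n4)cc3)CC2)c1` gives 93.5%

In a functional assay on T47D cells (Homo sapiens) for inhibition, read by CCK-8 assay, with a stated time of 72 h, tested at 10 uM (a lower number here means less inhibition of growth, a higher number more inhibition of growth at the concentration tested), compound 1 holds the highest of the three numbers, but its steps to the other two are small: a number 2.4 percentage points lower from compound 1 to compound 2 (within the scatter) and a number 1.5 percentage points lower from compound 1 to compound 3 (within the scatter) both fall inside the usual scatter, as does a number 0.9 percentage points higher from compound 2 to compound 3 (within the scatter). On the numbers shown, the three compounds cannot be told apart in this assay.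

Compound 4 `CN(C)C(=O)c1cc2cnc(Nc3ccc(NC(=O)C4(C(=O)Nc5cccc(Br)c5)CC4)cc3)nc2n1C1CCCC1` is the next member. The change from compound 1 is 3-bromophenyl in place of 4-chlorophenyl on an amide-type nitrogen. Within the data shown here, two measured steps bear on it. The move from compound 1 to compound 2 exchanges 4-chlorophenyl for 3-chlorophenyl on the same amide-type nitrogen, and a number 2.4 percentage points lower from compound 1 to compound 2 (within the scatter) shows no effect beyond scatter. The move from compound 2 to compound 3 exchanges one substituent for another on that aromatic carbon, and a number 0.9 percentage points higher from compound 2 to compound 3 (within the scatter) is again flat. Nothing in the series points to a change beyond scatter for a 3-bromophenyl group here.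

Compound 4 is therefore expected to stay close to compound 1, with a number 2 percentage points lower from compound 1 to compound 4 (within the scatter) as the expected step. The estimate for compound 4 is 93%, with a range from 84% to 99%, the lower end allowing for the scatter seen between the three measured compounds.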

Compound 4, percent growth inhibition at one concentration: 94.6%
Compound 4: the middle estimate sits 1.6 percentage points below what was measured; low and high end bracket the measured number.
By their numbers in this assay, from the lowest: compounds 2, 3, 4 and 1 (each within the scatter of the next).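

In this assay, among these compounds, the 3-bromophenyl group on the amide-type nitrogen brings bromine into the series for the first time, and the step to it from the 4-chlorophenyl group is a number 0.4 percentage points lower from compound 1 to compound 4 (within the scatter) while the exchanges on the aromatic carbon read a number 2 percentage points higher from compound 2 to compound 4 (within the scatter) and a number 1.1 percentage points higher from compound 3 to compound 4 (within the scatter) with no step beyond the scatter. The flat picture at this position therefore now holds for bromo as well as chloro and methoxy, and compounds 1, 2, 3 and 4 cannot be told apart in this single-concentration read-out. No measured data on these compounds give a cause for this flatness.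

As far as these compounds go, whether a more different group on this phenyl ring, such as an amine or a carboxylic acid, or a longer chain in place of the phenyl ring on the amide-type nitrogen, would give a step beyond the scatter stays open. Also open, from the compounds shown here alone, is whether compounds 1, 2, 3 and 4 would separate at lower concentrations, where a full concentration-response comparison could show differences that a single tested concentration cannot.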